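Isobutyl to sec-butyl on the amine nitrogen: an inactive series

A few compounds are considered here, and "the series" means these few. Any claim that something is new, unique, unknown or untested is made for them only; others in the source may bear on it.

Measured so far:
- compound 1, `CCC(C)NC(=C\C(=O)/C=C/c1ccc(O)c(OC)c1)/C=C/c1ccc(O)c(OC)c1`: in a functional assay on CHO-K1 cells (Cricetulus griseus) for inhibition, read by MTT assay, with a stated time of 72 h (a higher number here means a weaker inhibitor, a lower number a stronger inhibitor), compound 1 gives > 25000 nM, which is a limit of the assay.
- compound 2, `COc1cc(/C=C/C(=O)/C=C(/C=C/c2ccc(OC(C)=O)c(OC)c2)NCC(C)C)ccc1OC(C)=O`: in this assay compound 2 gives > 25000 nM, again a limit.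
- compound 3, `COc1cc(/C=C/C(=O)/C=C(/C=C/c2ccc(O)c(OC)c2)NCC(C)C)ccc1O`: in this assay compound 3 gives > 25000 nM, also a limit.

Compound 3 and compound 1 differ by one change, (sec-butyl in place of isobutyl on an amine nitrogen), and the step that the two limits leave unreadable from compound 3 to compound 1 cannot be sized, since both values are limits. The difference between the core of compound 2 and the core of compound 3 is not broken down here. Compound 4, `CCC(C)NC(=C\C(=O)/C=C/c1ccc(OC(C)=O)c(OC)c1)/C=C/c1ccc(OC(C)=O)c(OC)c1`, is not yet measured; it stands to compound 2 as compound 1 stands to compound 3, the same change, (sec-butyl in place of isobutyl on an amine nitrogen). Going by the values given here, the only guide is the limit of > 25000 nM in this assay, at which 3 of the 3 values shown sit. Among the compounds with values here, with no measured step of any size in view, compound 4 is expected to stay at that limit too, giving an estimated step that the limit leaves unreadable from compound 2 to compound 4. The estimate for compound 4 in this assay is therefore 40000 nM, between 20000 nM and 120000 nM.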

Compound 4, half-maximal inhibitory concentration: > 25000 nM
Compound 4: no number, only a limit (the forecaster's own chance of this, stated with the estimate: 90%); the middle value lies beyond the limit too.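

Compound 2 and compound 4 both give a limit of the assay rather than a number, so no step can be read for the change from isobutyl to sec-butyl on the amine nitrogen: the limit of > 25000 nM in this assay, at which 4 of the 4 values shown sit.

The compounds shown leave open how strongly any of them inhibits in this assay, and whether this change of group matters at all.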